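A few compounds are considered here, and "the series" means these few. Any claim that something is new, unique, unknown or untested is made for them only; others in the source may bear on it.

Measured compounds in the series:

- Compound 1, `COc1ccccc1N1CCN(C(=O)CCc2c(-c3ccccc3Br)[nH]c3ccc(C)cc23)CC1`, 89 nM
- Compound 2, `COc1ccccc1N1CCN(C(=O)CCc2c(-c3ccc(Cl)cc3)[nH]c3ccc(Cl)cc23)CC1`, 0.89 nM
- Compound 3, `Cn1c(-c2cccnc2)c(CCC(=O)N2CCC(O)(Cc3ccccc3)CC2)c2cc(Cl)ccc21`, 0.92 nM

All three were run in an assay on CHO cells for displacement of a labelled ligand from Substance-P receptor (Homo sapiens); a higher number here means a weaker inhibitor, a lower number a stronger inhibitor. Compound 3 stands second highest of the three numbers. For the measured compounds named here, its nearest neighbour is compound 2, whose value is within the scatter of the one for compound 3, so no order between the two can be read from these numbers. The furthest is compound 1, whose value is well beyond the scatter above that of compound 3; the two share neither the core nor the amide-side group, so that gap is not tied to any single change.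

Compound 4, `Cn1c(-c2ccccn2)c(CCC(=O)N2CCC(O)(Cc3ccccc3)CC2)c2cc(Cl)ccc21`, is the untested member. It differs from compound 3 in one place: pyridin-2-yl in place of pyridin-3-yl on an aromatic carbon. Going by the values given here, no pair among the measured compounds differs in only this way, so there is no directly comparable step in this assay. The expectation is a small move, if any, most likely toward a slightly higher number; the step from compound 3 to compound 4 is estimated at a 1.6-fold higher number from compound 3 to compound 4 (0.21 log units; within the scatter). Compound 4 is therefore expected to give about 1.5 nM in this assay, within a range of 0.4 nM to 6 nM.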

Compound 4, half-maximal inhibitory concentration: 2.9 nM
For compound 4 the middle estimate is 1.9-fold (0.29 log units) below the measured one; measured number inside the range.
By their numbers in this assay, from the lowest: compounds 2 and 3 (each within the scatter of the next); then compound 4; then compound 1.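

At this place on the shared core, an aromatic carbon next to the ring nitrogen, this assay responds to pyridin-2-yl in place of pyridin-3-yl with a 3.2-fold higher number from compound 3 to compound 4 (0.50 log units; beyond the scatter), a modest step but one beyond the scatter. For the compounds shown here, this is the first comparison that differs in only one place, and it shows that the read-out at this position depends on how the pyridine ring is joined, even though the leaving and entering groups match in heavy atoms, hydrogen-bond donors, hydrogen-bond acceptors and net charge. No measured information at hand bears on what lies behind this step.

Still open, from the compounds shown here alone, is how pyridin-4-yl or pyrimidin-5-yl at the same place would compare with compound 3 and compound 4 in this assay, which would show whether this single step is part of a wider trend. Going by these compounds alone, also open is whether the same exchange gives a step of similar size with the amide-side group of compound 2 in place of the one shared by compound 3 and compound 4.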